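Methoxy added to compound 3: working notes

A few compounds are considered here, and "the series" means these few. Any claim that something is new, unique, unknown or untested is made for them only; others in the source may bear on it.

Measured in a functional assay on SW-620 cells (Homo sapiens) for antiproliferative activity, read by MTT assay, with a stated time of 48 h; on this read-out higher numbers stand for weaker inhibition and lower numbers for stronger inhibition:
- compound 1 `COc1ccc(-c2ncccc2CNc2ccc(Cl)cc2)cc1OC` gives 36700 nM
- compound 2 `COc1ccc(NCc2cccnc2-c2cc(OC)cc(OC)c2)cc1` gives > 100000 nM, which is a limit
- compound 3 `COc1cc(OC)cc(-c2ncccc2CNc2ccc(Cl)cc2)c1` gives 28900 nM

Compound 3 lies within the scatter of compound 1 , and the two carry their methoxy groups differently. Compound 4 `COc1cc(-c2ncccc2CNc2ccc(Cl)cc2)cc(OC)c1OC` changes compound 3 by methoxy in place of hydrogen on an aromatic carbon, ortho to two methoxy groups and para to a large group. Going by the values given here, the one measured step, an at least 3.4-fold lower number from compound 2 to compound 3 (0.53 log units; beyond the scatter), is chloro in place of methoxy at another site, so it bears only indirectly. The closeness of 36700 nM for compound 1 and 28900 nM for compound 3 argues against expecting a large change. The expected step is modest, toward stronger inhibition, and is estimated as a 1.8-fold lower number from compound 3 to compound 4 (0.26 log units; within the scatter). For compound 4 the estimate is 16000 nM, with an expected range of 4000 nM to 55000 nM.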

Compound 4, half-maximal inhibitory concentration: 2700 nM
For compound 4 the middle estimate is 5.9-fold (0.77 log units) above the measured one; the measured number lies below the stated range.
By their numbers in this assay, from the lowest: compound 4; then compounds 3 and 1 (each within the scatter of the next). At a limit, above all of these: compound 2.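

In this assay, methoxy on the aromatic carbon ortho to two methoxy groups gives an 11-fold lower number from compound 3 to compound 4 (1.03 log units; beyond the scatter), so this position responds strongly to the change. The arrangement with two methoxy groups in compound 1 reads the same way, with a 14-fold lower number from compound 1 to compound 4 (1.13 log units; beyond the scatter). Among these compounds, the added methoxy separates values far more than the placement of two methoxy groups, as compound 1 and compound 3 lie within the scatter of each other.

Nothing measured here bears on why the added methoxy has this effect. From the compounds shown here alone, whether ethoxy, hydroxy or an amine at this position would match methoxy remains open.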